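Aryl Group Swap on the Carbonyl Carbon

The source may hold more compounds than are shown below. What is called first, only, known or untested is meant among the compounds shown, and "the series" means these compounds.

Compound 1 `CCCCCCCCCCCCn1nnc(C(NC(=O)c2c(C(C)C)cccc2C(C)C)c2ccccc2)n1`: 810 nM
Compound 2 `CCCCCCCCCCCCn1nnc(C(NC(=O)c2ccc(OC)cc2)c2ccccc2)n1`: 600 nM

In an assay on microsomes from liver for inhibition of sterol O-acyltransferase 1 (Rattus norvegicus) (a lower number here means a stronger inhibitor, a higher number a weaker inhibitor), compound 2 gives 600 nM, the lowest of the two numbers, and the nearest number belongs to compound 1. Within the data shown here, the one measured step, a 1.4-fold lower number from compound 1 to compound 2 (0.13 log units; within the scatter), changed the aryl group on the carbonyl carbon and stayed within the scatter. Compound 3 `CCCCCCCCCCCCn1nnc(C(NC(=O)c2cccc([N+](=O)[O-])c2)c2ccccc2)n1` differs from compound 2 in 3-nitrophenyl in place of 4-methoxyphenyl on a carbonyl carbon. That step alone bears on the change, and it is small, so no step beyond the scatter is expected, a 1.2-fold higher number from compound 2 to compound 3 (0.07 log units; within the scatter). Compound 3 is estimated at 700 nM, within 250 nM to 2000 nM.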

Compound 3, half-maximal inhibitory concentration: 80 nM
Beside the measured number, compound 3's estimate is 8.8-fold (0.94 log units) above it; the measured number lies below the stated range.
By their numbers in this assay, from the lowest: compound 3; then compounds 2 and 1 (each within the scatter of the next).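

The aryl group on the carbonyl carbon does move the number in this assay, which the earlier pair, within the scatter of each other, did not show: 3-nitrophenyl in place of 4-methoxyphenyl gives a 7.5-fold lower number from compound 2 to compound 3 (0.88 log units; beyond the scatter). In place of 2,6-diisopropylphenyl, the same group gives a 10-fold lower number from compound 1 to compound 3 (1.01 log units; beyond the scatter). Nothing available explains these steps.

As far as these compounds go, it remains open whether the gain belongs to the nitro group itself or to where it sits on the ring. A 4-nitrophenyl, 3-methoxyphenyl or 3-aminophenyl group would help separate the two.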